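The source may report more compounds than this note shows. Statements on the series, on what has been measured and on what is new or still open speak of the compounds shown alone.

In a functional assay on HL-60 cells (Homo sapiens) for antiproliferative activity, with a stated time of 72 h (on this read-out higher numbers stand for weaker inhibition and lower numbers for stronger inhibition), compound 1 `Nc1ncnn2c([C@@H]3O[C@H](CO)[C@@H](O)[C@H]3O)cc(C#Cc3ccccc3)c12` gives > 100000 nM, which is a limit. Compound 2 `Nc1ncnn2c([C@@H]3O[C@H](CO)[C@@H](O)[C@H]3O)cc(-c3ccccc3)c12` gives > 100000 nM, also a limit. Compound 3 `COc1ccc(-c2cc([C@@H]3O[C@H](CO)[C@@H](O)[C@H]3O)n3ncnc(N)c23)cc1` gives > 100000 nM, again a limit and not a number. The three steps, a step that the two limits leave unreadable from compound 1 to compound 2, a step that the two limits leave unreadable from compound 1 to compound 3 and a step that the two limits leave unreadable from compound 2 to compound 3, therefore show no size. Compound 4 `Nc1ncnn2c([C@@H]3O[C@H](CO)[C@@H](O)[C@H]3O)cc(/C=C/c3ccccc3)c12` carries 2-phenylethenyl in place of 4-methoxyphenyl on an aromatic carbon. For the measured compounds named here, the only guide for this change is the limit of > 100000 nM in this assay, at which 3 of the 3 values shown sit. On that ground, a number no higher from compound 3 to compound 4 (the limit leaves the size open) is expected to show no change beyond the scatter, in either direction. Compound 4 is estimated at 100000 nM, with an expected range from 30000 nM to 300000 nM.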

Compound 4, half-maximal inhibitory concentration: 2000 nM
Compound 4: the middle estimate sits 50-fold (1.70 log units) above what was measured; measured number outside the range, below it.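

Across the compounds shown, this carbon of the five-membered aromatic ring tolerates a change that turns an unreadable result into a measured one in this assay: an at least 50-fold lower number from compound 3 to compound 4 (1.69 log units; beyond the scatter), an at least 50-fold lower number from compound 2 to compound 4 (1.69 log units; beyond the scatter) and an at least 50-fold lower number from compound 1 to compound 4 (1.69 log units; beyond the scatter). Among groups of this kind, only 2-phenylethenyl gives a number, so the outcome depends on the exact group at this place. Compound 4 alone has left the limit: the limit of > 100000 nM in this assay, at which 3 of the 4 values shown sit.

The compounds shown leave open how far below the limit the other three lie. They also leave open whether an amine or a longer alkyl chain at this place would give a number in this assay.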